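This account rests on a few compounds, and the source may have more. Where it says the series, first, only, none or still open, it means among the compounds named here.

Compound 1 `Cc1c(OCCCCOc2ccc(C(=O)O)cc2)ccc(C(=O)CC2CCCC2)c1O` gives 824 nM in an assay on HEK293 cells for positive allosteric modulation of metabotropic glutamate receptor 2 (Rattus norvegicus), read by thallium flux, with a stated time of 2.5 min; on this read-out higher numbers stand for an effect only at larger amounts of compound and lower numbers for an effect already at smaller amounts; compound 2 `Cc1c(OCCCCOc2ccccc2C(=O)O)ccc(C(=O)CC2CCCC2)c1C` gives 2580 nM in this assay, so compound 1 holds the lower of the two numbers, with compound 2 beyond the scatter above it. Compound 3 `Cc1c(OCCCCOc2ccc(C(=O)O)cc2F)ccc(C(=O)CC2CCCC2)c1O` carries one difference from compound 1: fluoro in place of hydrogen on an aromatic carbon, a fluoro in place of hydrogen on an aromatic carbon. Within the data shown here, no measured pair shows such a change, so the step is expected to stay within the scatter, in either direction. Compound 3 is estimated at 700 nM in this assay, within 300 nM to 1800 nM, the expected step being a 1.2-fold lower number from compound 1 to compound 3 (0.07 log units; within the scatter).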

Compound 3, half-maximal effective concentration: 639 nM
Compound 3: the middle estimate sits 1.1-fold (0.04 log units) above what was measured, and the stated range covers the measured number.
By their numbers in this assay, from the lowest: compounds 3 and 1 (each within the scatter of the next); then compound 2.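

The 4-carboxyphenyl to 4-carboxy-2-fluorophenyl exchange gives the series its first single-place pair, with a 1.3-fold lower number from compound 1 to compound 3 (0.11 log units; within the scatter) in this assay. This aromatic carbon, ortho to a large group and meta to the carboxy group, therefore takes a fluoro with no step beyond the scatter. No measurement on hand bears on the reason for this result.

Open, going by these compounds, is whether chloro, methoxy or an amine on this same carbon would also stay within the scatter. Also open, on these data alone, is whether an amide or a tetrazole could stand in place of the carboxylic acid.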